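Compound 3 and the Limit of Cytotoxicity

The source may hold more compounds than are shown below. What is called first, only, known or untested is meant among the compounds shown, and "the series" means these compounds.

Compound 1 `Nc1ncnc2c1c([N+](=O)[O-])cn2[C@@H]1C=C(CO)[C@@H](O)[C@H]1O`: > 300000 nM, a limit
Compound 2 `C=Cc1cn([C@@H]2C=C(CO)[C@@H](O)[C@H]2O)c2ncnc(N)c12`: > 300000 nM, a limit
Compound 3 `C#Cc1cn([C@@H]2C=C(CO)[C@@H](O)[C@H]2O)c2ncnc(N)c12`: not yet measured

All values come from an ADME assay on HepG2 2.2.15 cells (Homo sapiens) for cytotoxicity, read by neutral red uptake, with a stated time of 24 h; on this read-out lower numbers stand for stronger inhibition and higher numbers for weaker inhibition. Compound 2 has no numerical value there, only a limit of > 300000 nM. The same holds for compound 1, and the pair shares one ceiling: the limit of > 300000 nM in this assay, at which 2 of the 2 values shown sit. Among the measured compounds shown here, the only measured step, a step that the two limits leave unreadable from compound 1 to compound 2, therefore has no readable size or direction.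

Compound 3 carries ethynyl in place of vinyl on an aromatic carbon, that is, ethynyl in place of vinyl on an aromatic carbon. With compound 2 at the limit of > 300000 nM, the data offer no measured size for this change, so no shift beyond the scatter is expected in this assay. The expected change is a number no higher from compound 2 to compound 3 (the limit leaves the size open). For compound 3 the estimate is 300000 nM, with an expected range of 100000 nM to 450000 nM.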

Compound 3, half-maximal inhibitory concentration: > 300000 nM
Compound 3: a limit, no number (the forecaster's own chance of this, stated with the estimate: 75%); the middle value sits exactly at the limit.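

Compound 3 gives > 300000 nM in this assay, which is a limit and not a number. No step among compound 1, compound 2 and compound 3 can be read, because all three stop at one ceiling: the limit of > 300000 nM in this assay, at which 3 of the 3 values shown sit.

The compounds shown leave open whether nitro, vinyl and ethynyl differ at all in this assay.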